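The source may hold more compounds than are shown below. What is called first, only, known or untested is meant among the compounds shown, and "the series" means these compounds.

Measured compounds:
compound 1 `Cc1cc(C(=O)O)nn1Cc1cc(Br)ccc1OCc1ccccc1` — 6.31 nM
compound 2 `Cc1cc(C(=O)O)nn1C(C)c1cc(Cl)ccc1OCc1ccccc1` — 10 nM
compound 3 `Cc1cc(C(=O)Nc2ccccn2)nn1Cc1cc(Cl)ccc1OCc1ccccc1` — 126 nM

In an assay on CHO-K1 cells for displacement of a labelled ligand from prostaglandin E2 receptor EP1 subtype (Homo sapiens) (on this read-out lower numbers stand for stronger inhibition and higher numbers for weaker inhibition), compound 3 stands at the highest of the three numbers; compound 2 gives 10 nM and compound 1 gives 6.31 nM, both beyond the scatter below compound 3. Compound 4 `Cc1cc(NC(=O)CC2CCCCC2)nn1Cc1cc(Cl)ccc1OCc1ccccc1` has not been measured in this assay.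

((cyclohexylmethyl)carbonyl)amino in place of (pyridin-2-yl)carbamoyl on an aromatic carbon

Within the data shown here, no step between measured compounds matches this change. Compounds 1 and 2 carry a carboxylic acid where compound 3 carries an amide, and compound 4 carries no acid either, so no return toward those two is expected. The step from compound 3 to compound 4 in this assay is expected to be small, in the weaker direction or none beyond the scatter, a 2.0-fold higher number from compound 3 to compound 4 (0.30 log units; within the scatter). Compound 4 is estimated at 250 nM, within 60 nM to 1000 nM.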

Compound 4, half-maximal inhibitory concentration: 6.31 nM
Compound 4: the middle estimate sits 40-fold (1.60 log units) above what was measured, and the stated range ends above it.
By their numbers in this assay, from the lowest: compounds 1, 4 and 2 (each within the scatter of the next); then compound 3.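

In this assay, ((cyclohexylmethyl)carbonyl)amino in place of (pyridin-2-yl)carbamoyl on this aromatic carbon gives a 20-fold lower number from compound 3 to compound 4 (1.30 log units; beyond the scatter) and is a large change. Compound 4 carries no carboxylic acid and gives 6.31 nM, so a low number in this series does not depend on that group at this position. No evidence on hand accounts for the step.

The change swaps the ring for a cyclohexylmethyl group and reverses the amide at once, and these two cannot be separated here. A (cyclohexylmethyl)carbamoyl group or a ((pyridin-2-yl)carbonyl)amino group at this position would tell them apart.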